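Octylsulfonamide benzoic acids: a ketone bridge tested

This account rests on a few compounds, and the source may have more. Where it says the series, first, only, none or still open, it means among the compounds named here.

Compound 1 `CCCCCCCCS(=O)(=O)Nc1ccc(-c2ccccc2OC)cc1C(=O)O`: 27600 nM
Compound 2 `CCCCCCCCS(=O)(=O)Nc1ccc(-c2ccc(O)cc2)cc1C(=O)O`: 47300 nM

For the measured compounds named here, in an assay on mitochondria (strain BALB/c) for inhibition of glycerol-3-phosphate acyltransferase 1, mitochondrial (Mus musculus), read by scintillation counting, with a stated time of 10 min (a higher number here means a weaker inhibitor, a lower number a stronger inhibitor), compound 2 gives the higher of the two numbers so far, yet its nearest neighbour, compound 1, lies within the scatter, so the two cannot be told apart a 1.7-fold higher number from compound 1 to compound 2 (0.23 log units; within the scatter). Compound 3 `CCCCCCCCS(=O)(=O)Nc1ccc(C(=O)c2ccc(OC)cc2)cc1C(=O)O` changes the same position again: (4-methoxyphenyl)carbonyl in place of 4-hydroxyphenyl on an aromatic carbon, on an aromatic carbon of a six-membered aromatic ring of carbon only, meta to a carboxy group and para to a large group. Going by the values given here, only one measured step bears on this, the swap from compound 1 to compound 2, and it stayed within the scatter. Among the compounds with values here, that step exchanged one aryl group for another; here a carbonyl enters between the ring of the core and the methoxyphenyl, a change of a different kind, so the one precedent is only a loose guide. On that basis no step beyond the scatter is expected in this assay. Compound 3 is therefore estimated at 35000 nM, with a range from 12000 nM to 100000 nM. The expected step is a 1.4-fold lower number from compound 2 to compound 3 (0.13 log units; within the scatter).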

Compound 3, half-maximal inhibitory concentration: 44300 nM
For compound 3 the middle estimate is 1.3-fold (0.10 log units) below the measured one, within the range that was stated.
By their numbers in this assay, from the lowest: compounds 1, 3 and 2 (each within the scatter of the next).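

In this assay the ketone-bridged group gives two steps: a 1.1-fold lower number from compound 2 to compound 3 (0.03 log units; within the scatter) and, set against the directly attached 2-methoxyphenyl, a 1.6-fold higher number from compound 1 to compound 3 (0.21 log units; within the scatter). The group that enters has 10 heavy atoms, 0 hydrogen-bond donors and a double bond outside aromatic rings, where the 4-hydroxyphenyl that leaves has 7 heavy atoms and 1 hydrogen-bond donor, and even this larger exchange, of a different kind from the first, stays within the scatter, so that the three compounds cannot be told apart and the position has so far shown no measurable response to any of its three groups. No measurement at hand offers an explanation for this flat result.

Going by these compounds, it remains open whether any group at this position can move the number beyond the scatter, for example an amine or a carboxylic acid in place of the methoxy group of the (4-methoxyphenyl)carbonyl. Also open, on these data alone, is how much the octyl chain, common to all three compounds, contributes, which a shorter or a longer chain on the same core would show.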